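Switching the ring on the sulfonyl-bound chain carbon

The source may report more compounds than this note shows. Statements on the series, on what has been measured and on what is new or still open speak of the compounds shown alone.

Compound 1 `O=S(=O)(CC1=NCCO1)C1=NNCC1c1ccccc1` was examined in a functional assay, read by Griess assay, with a stated time of 150 min, tested at 100 ug/mL; on this read-out lower numbers stand for a weaker effect and higher numbers for a stronger effect at the one concentration tested. In this assay compound 1 is recorded as "not active" (no number reported), so no single number marks where it stands; it can only be placed at the weak end of the read-out. Compound 2 `Cc1ccc(C2CNN=C2S(=O)(=O)CC2=NCCO2)cc1`, which shares the same core and the same side chain on the sulfonyl group, gives 51.4% in this assay, which shows that a clear effect can be reached within this series. Going by the values given here, no step between these two compounds is given here, so only their two values can be set side by side.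

Compound 3 `O=S(=O)(CC1=NCCS1)C1=NNCC1c1ccccc1` has not yet been measured. It differs from compound 1 by a group of 5 heavy atoms (3 carbon, 1 nitrogen, 1 sulfur; one five-membered non-aromatic ring with 2 hetero atoms) in place of a group of 5 heavy atoms (3 carbon, 1 nitrogen, 1 oxygen; one five-membered non-aromatic ring with 2 hetero atoms), on a saturated chain carbon bound to a sulfonyl sulfur. Because compound 1 is recorded as "not active" (no number reported) in this assay, the starting point for this change is a weak effect. From the compounds shown here alone, without any measured pair for the same change, the size and direction of the step are unknown; a shift beyond the scatter in either direction is possible, and no shift at all is possible. Compound 3 is therefore expected to give about 20% in this assay, with a range from 0% to 55%.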

Compound 3, a percentage reported as activity, at one concentration (the size of the read-out at that concentration, not a potency): "not active" (no number reported)
No number was reported for compound 3; the estimate stays without a comparison.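

In this assay compound 1 stands at "not active" (no number reported) and compound 3 at "not active" (no number reported), so no step can be read between these two compounds. Nothing given here bears on this result. The compounds shown leave open how the sulfur-containing ring would act on a compound with a measurable effect, such as compound 2.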